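A smaller group on the shared core

A few compounds are considered here, and "the series" means these few. Any claim that something is new, unique, unknown or untested is made for them only; others in the source may bear on it.

In a physicochemical assay for solubility, in phosphate buffer, measured as kinetic solubility, with a stated time of 1 h, at pH 7.4 (a higher number here means a more soluble compound, a lower number a less soluble compound), compound 1 `CCNC(=O)Nc1ccc(-c2nccc([C@]34CCOC[C@H]3C4)n2)cc1` gives 125 ug/mL, and compound 2 `CCNC(=O)Nc1ccc(-c2nccc(C34CCOCC3C4)n2)cc1` gives 111 ug/mL. Compound 2 therefore stands within the scatter of compound 1, and these two numbers are all that has been measured so far. Going by the values given here, the one measured step is a 1.1-fold lower number from compound 1 to compound 2 (0.05 log units; within the scatter), and it concerns only (the fact that one of compounds 1 and 2 is drawn with a defined configuration and the other without, at the place where they differ). It says nothing about a change of group.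

Compound 3 `CCNC(=O)Nc1ccc(-c2nccc(C3=CCOCC3)n2)cc1` has not yet been measured. Its difference from compound 2 is a group of 6 heavy atoms (5 carbon, 1 oxygen; one six-membered non-aromatic ring with 1 hetero atom) in place of a group of 7 heavy atoms (6 carbon, 1 oxygen; one three-membered non-aromatic ring of carbon only, one six-membered non-aromatic ring with 1 hetero atom), on an aromatic carbon. The three-membered non-aromatic ring of carbon only is gone, and a double bond outside aromatic rings comes in, on the same aromatic carbon. Among the compounds with values here, no measured step covers such an exchange, so the expectation stays with compound 2 at 111 ug/mL, with no step beyond the scatter foreseen in this assay and a range left wide on both sides. The estimate corresponds to an expected 1.0-fold lower number from compound 2 to compound 3 (0.00 log units; within the scatter). For compound 3 the expected value is 110 ug/mL, within an estimated range from 45 ug/mL to 260 ug/mL.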

Compound 3, solubility: 24 ug/mL
Beside the measured number, compound 3's estimate is 4.6-fold (0.66 log units) above it; measured number outside the range, below it.
By their numbers in this assay, from the lowest: compound 3; then compounds 2 and 1 (each within the scatter of the next).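

In this assay, the group on this aromatic carbon of the six-membered aromatic ring with 2 nitrogen proves to matter: exchanging the group with the three-membered ring for the one with a double bond outside aromatic rings gives a 4.6-fold lower number from compound 2 to compound 3 (0.67 log units; beyond the scatter), and the same exchange gives a 5.2-fold lower number from compound 1 to compound 3 (0.72 log units; beyond the scatter). Both steps lie beyond the scatter. The earlier comparison concerned only how the configuration was drawn and stayed within it. Going by these compounds alone, these are the first measured steps that involve a change of the group itself. Nothing available explains why this exchange lowers the number.

The exchange removes the three-membered ring and brings in the double bond in a single step, so the compounds shown cannot separate the contribution of one from that of the other; a six-membered ring with 1 hetero atom carrying neither feature would be needed for that. They also leave open how this position would respond to a quite different group, such as an amine or a carboxylic acid, since every group shown here is built on a six-membered non-aromatic ring with 1 hetero atom.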